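Hydroxy added to compound 3: working notes

A few compounds are considered here, and "the series" means these few. Any claim that something is new, unique, unknown or untested is made for them only; others in the source may bear on it.

Three compounds on a shared core have numbers in a functional assay on MDA-MB-468 cells (Homo sapiens) for antiproliferative activity, read by MTT assay, with a stated time of 72 h; on this read-out lower numbers stand for stronger inhibition and higher numbers for weaker inhibition. Compound 1 `COc1cc(-c2nccn2-c2ccc(F)cc2)cc(OC)c1OC` gives 62200 nM, compound 2 `COc1cc(-c2nccn2-c2ccc(Br)cc2)cc(OC)c1OC` gives 2700 nM, and compound 3 `COc1ccc(-n2ccnc2-c2cc(OC)c(OC)c(OC)c2)cc1` gives 500 nM. Compound 3 holds the lowest number of the three, and both steps to it lie beyond the scatter: a 120-fold lower number from compound 1 to compound 3 (2.09 log units; beyond the scatter) and a 5.4-fold lower number from compound 2 to compound 3 (0.73 log units; beyond the scatter).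

Compound 4 `COc1ccc(-n2ccnc2-c2cc(OC)c(OC)c(OC)c2)cc1O` keeps all of compound 3 and adds one group: hydroxy in place of hydrogen on an aromatic carbon. This is hydroxy in place of hydrogen on an aromatic carbon, ortho to a methoxy group and meta to a large group.

For the measured compounds named here, no measured step adds a group at this carbon, so the evidence is indirect. The three measured steps exchange a single substituent on the same ring, and all are beyond the scatter, including a 23-fold lower number from compound 1 to compound 2 (1.36 log units; beyond the scatter). This ring therefore appears responsive in this assay. The only oxygen-bearing substituent measured there, in compound 3 at 500 nM, gave the lowest number, which tentatively favours a fall rather than a rise. The expected change is modest and uncertain, an estimated 4.2-fold lower number from compound 3 to compound 4 (0.62 log units; beyond the scatter). The estimate for compound 4 is 120 nM, with an expected range from 20 nM to 700 nM.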

Compound 4, half-maximal inhibitory concentration: 300 nM
Beside the measured number, compound 4's estimate is 2.5-fold (0.40 log units) below it, within the range that was stated.
By their numbers in this assay, from the lowest: compounds 4 and 3 (each within the scatter of the next); then compound 2; then compound 1.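

In this assay, for the compounds shown here, the new step, a 1.7-fold lower number from compound 3 to compound 4 (0.22 log units; within the scatter), is the first measured change at this carbon, and unlike the three substituent exchanges on the same ring, it stays within the scatter. Hydroxy in place of hydrogen, ortho to a methoxy group and meta to a large group, is therefore accommodated in this assay, with compound 4 and compound 3 indistinguishable on these numbers, so the responsiveness seen in those exchanges does not carry over to this change. No measurement available here bears on the reason for this outcome.

On these data alone, whether this carbon accepts other groups remains open: an amine, a carboxylic acid or a longer chain such as ethoxy in place of the hydroxy would show whether the number stays flat here or moves beyond the scatter. Going by these compounds alone, also open is whether hydroxy at this carbon would give a similarly small step if the methoxy group were replaced by the bromo or fluoro substituent of the earlier compounds.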